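Swapping the anilide ring: nitro in place of chloro

This account rests on a few compounds, and the source may have more. Where it says the series, first, only, none or still open, it means among the compounds named here.

Measured so far:
- compound 1, `O=C(CSc1nc(Nc2ccccc2)c2ccccc2n1)Nc1cccc(F)c1`: > 50000 nM
- compound 2, `O=C(CSc1nc(Nc2ccccc2)c2ccccc2n1)Nc1cccc(Cl)c1`: 16500 nM
- compound 3, `C=CC(=O)Nc1cccc(NC(=O)CSc2nc(Nc3ccccc3)c3ccccc3n2)c1`: 10200 nM

In a functional assay on MDA-MB-231 cells (Homo sapiens) for inhibition, read by MTT assay, with a stated time of 72 h (on this read-out lower numbers stand for stronger inhibition and higher numbers for weaker inhibition), compound 1 reaches only the assay limit, > 50000 nM. Compound 2 gives 16500 nM, the higher of the two numbers recorded, while compound 3 gives 10200 nM; the two differ by a 1.6-fold lower number from compound 2 to compound 3 (0.21 log units; within the scatter), so nothing separates them. Changing the group on the aromatic ring of compound 1 produced an at least 3.0-fold lower number from compound 1 to compound 2 (0.48 log units; beyond the scatter) and an at least 4.9-fold lower number from compound 1 to compound 3 (0.69 log units; beyond the scatter), both at least modest, the first being a limit-based step because of the limit of > 50000 nM in this assay, at which 1 of the 3 values shown sits.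

Compound 4, `O=C(CSc1nc(Nc2ccccc2)c2ccccc2n1)Nc1ccc([N+](=O)[O-])cc1`, has not yet been measured. Its change from compound 2 is 4-nitrophenyl in place of 3-chlorophenyl on an amide-type nitrogen. Within the data shown here, no measured step swaps one whole aromatic ring for another on that amide nitrogen; the steps from compound 1 show that altering this ring can move the number, but the step from compound 2 to compound 3 shows it need not. For compound 4 a step of a 1.3-fold lower number from compound 2 to compound 4 (0.10 log units; within the scatter) is therefore expected, within the scatter. Compound 4 is estimated at 13000 nM, between 5000 nM and 40000 nM.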

Compound 4, half-maximal inhibitory concentration: 16800 nM
Estimate against measurement, compound 4: 1.3-fold (0.11 log units) below; measured number inside the range.
By their numbers in this assay, from the lowest: compounds 3, 2 and 4 (each within the scatter of the next). At a limit, above all of these: compound 1.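

In this assay, the whole-ring swap on the amide-type nitrogen gives a 1.0-fold higher number from compound 2 to compound 4 (0.01 log units; within the scatter), and the comparison with the acrylamide-bearing ring gives a 1.6-fold higher number from compound 3 to compound 4 (0.22 log units; within the scatter). This ring can therefore carry a chloro, a nitro or a (vinylcarbonyl)amino group, in different places, without any separation among compound 2, compound 3 and compound 4, so a large change in the group need not move the number. Compound 1 stays apart, with an at least 2.9-fold lower number from compound 1 to compound 4 (0.47 log units; beyond the scatter), but that step rests on a limit: the limit of > 50000 nM in this assay, at which 1 of the 4 values shown sits.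

In 4-nitrophenyl, both the group and its place on the ring differ from 3-chlorophenyl, so the two changes cannot be told apart here. Going by these compounds, whether an amine or a carboxylic acid on this ring would bring the number clearly lower also remains open.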